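Thiophene in Place of Methoxyphenyl on the Shared Core

The source may hold more compounds than are shown below. What is called first, only, known or untested is meant among the compounds shown, and "the series" means these compounds.

Of the compounds shown here, two have been measured in an assay on Sf9 cells for inhibition of serine/threonine-protein kinase 4 (Homo sapiens), read by luminescence and ADP-Glo, with a stated time of 1 h, in the presence of a further agent that is not named here; a lower number here means a stronger inhibitor, a higher number a weaker inhibitor. Compound 1 `CN1C(=O)C(c2ccccc2F)N(C)c2nc(Nc3ccc(S(N)(=O)=O)cc3)ncc21` gives 75 nM, and compound 2 `COc1ccccc1C1C(=O)N(C)c2cnc(Nc3ccc(S(N)(=O)=O)cc3)nc2N1C` gives 251 nM. For the measured compounds named here, compound 2 thus stands at the higher of the two numbers, with compound 1 as its only neighbour, and the one measured step, a 3.3-fold higher number from compound 1 to compound 2 (0.52 log units; beyond the scatter), is modest but beyond the scatter.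

Compound 3 `CN1C(=O)C(c2cccs2)N(C)c2nc(Nc3ccc(S(N)(=O)=O)cc3)ncc21` differs from compound 2 by thiophen-2-yl in place of 2-methoxyphenyl on a saturated ring carbon. Going by the values given here, no measured step bears directly on exchanging the whole aryl group: the only known step, from compound 1 to compound 2, concerns a single substituent on that ring, so it serves only as a loose guide. It shows that what sits on this saturated ring carbon can move the number by a modest amount, and the loss of the methoxy-bearing ring makes a return toward the lower end of the two measured numbers plausible. Compound 3 is therefore expected to give an estimated 120 nM in this assay. The expected step is a 2.1-fold lower number from compound 2 to compound 3 (0.32 log units; beyond the scatter), a lower number, within an estimated range from 40 nM to 400 nM.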

Compound 3, half-maximal inhibitory concentration: 88 nM
Estimate against measurement, compound 3: 1.4-fold (0.13 log units) above; the measured number falls inside the stated range.
By their numbers in this assay, from the lowest: compounds 1 and 3 (each within the scatter of the next); then compound 2.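

In this assay, exchanging the whole aromatic group on this saturated ring carbon gives a 2.9-fold lower number from compound 2 to compound 3 (0.46 log units; beyond the scatter), so replacing the entire ring moves the number by a modest amount beyond the scatter, which the earlier step, confined to a single substituent on that ring, could not show. The second step, a 1.2-fold higher number from compound 1 to compound 3 (0.07 log units; within the scatter), shows that this assay does not separate thiophen-2-yl from 2-fluorophenyl, even though one is a five-membered aromatic ring with a sulfur atom and the other a six-membered aromatic ring of carbon only; among the three compounds, only the 2-methoxyphenyl group of compound 2 stands apart, beyond the scatter from both others. Nothing available here accounts for this difference.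

Going by these compounds, all three compounds carry an aromatic ring on this carbon, so it remains open how the number would respond to a cyclohexyl ring, a longer alkyl chain or an amine there. On these data alone, it also remains open whether the close agreement between thiophen-2-yl and 2-fluorophenyl would extend to other aromatic rings, such as a pyridine or a furan.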